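Amine change at the chain carbon of the shared core

The compounds below may be only part of what the source reports. "The series", "measured", "known", "first", "only" and "open" are said of these compounds alone.

Compound 3 `CCCN(C[C@@H](O)CNS(=O)(=O)c1cccc2ccccc12)C(C)(C)C` is the starting point of the step. For the measured compounds named here, in an assay on HEK293 cells for inhibition of sodium- and chloride-dependent glycine transporter 1 (Homo sapiens) (on this read-out lower numbers stand for stronger inhibition and higher numbers for weaker inhibition), compound 3 gives 1000 nM as its only number; two further entries for it report no single number. Two neighbours carry ring amines on the same chain. Compound 1 `O=S(=O)(NC[C@H](O)CN1CCCC1C1CC1)c1cccc2ccccc12` gives 501 nM; 1580 nM (2 entries) in this assay, and compound 2 `CC(C)C1CCCN1C[C@@H](O)CNS(=O)(=O)c1cccc2ccccc12` gives 200 nM; 1000 nM (2 entries). The repeated entries of each spread widely, as seen in the several entries of compound 1 in this assay, 501 nM; 1580 nM (2 entries) and (the several entries of compound 2 in this assay, 200 nM; 1000 nM (2 entries)), and the three measured compounds sit in one broad band in which no order can be read.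

Compound 4 `O=S(=O)(NC[C@H](O)CN1CCCCC1)c1cccc2ccccc12` is not yet measured. The change from compound 3: piperidin-1-yl in place of propyl(tert-butyl)amino on a saturated chain carbon, two bonds along the chain from an oxygen on a saturated carbon. Going by the values given here, no pair of measured compounds covers this exchange. Compound 3 with its acyclic amine gives 1000 nM, and the ring amines of compound 1 at 501 nM; 1580 nM (2 entries) and compound 2 at 200 nM; 1000 nM (2 entries) land in the same band. On that basis the step of a 1.5-fold higher number from compound 3 to compound 4 (0.18 log units; within the scatter) is expected to be small, a slight loss at most and within the scatter. Compound 4 is estimated at 1500 nM in this assay, with a range from 400 nM to 5000 nM.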

Compound 4, half-maximal inhibitory concentration: 3160 nM
Estimate against measurement, compound 4: 2.1-fold (0.32 log units) below; the measured number falls inside the stated range.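

In this assay, for the compounds shown here, the exchange of propyl(tert-butyl)amino for piperidin-1-yl on the saturated chain carbon gives a 3.2-fold higher number from compound 3 to compound 4 (0.50 log units; beyond the scatter), the first step at this position that can be read and one that lies beyond the scatter. The amine at this carbon is therefore not freely interchangeable, and this one exchange from an acyclic to a ring amine costs a modest amount on this read-out. The step rests on a single number for each of its two compounds, while repeated entries for a ring amine on the same chain spread widely, so its size is best held loosely: the several entries of compound 1 in this assay, 501 nM; 1580 nM (2 entries)

Going by these compounds, whether the higher number belongs to the ring itself or to the absence of a substituent on it stays open, since compound 1 and compound 2 carry substituted ring amines but no readable step links either of them to compound 4 or to compound 3. A piperidin-1-yl bearing an isopropyl group, or a morpholin-4-yl at the same chain carbon, would test these two readings directly against compound 4.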